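Methoxyphenyl positional isomers and fibroblast cytotoxicity

A few compounds are considered here, and "the series" means these few. Any claim that something is new, unique, unknown or untested is made for them only; others in the source may bear on it.

Compound 1 `COc1ccc(-c2cc(COC(Cc3cn(C4CCN(Cc5ccc([N+](=O)[O-])cc5)CC4)nn3)c3ccc(Br)cc3)on2)cc1` is the reference point of the series. In an ADME assay on cells (Fibroblast, Homo sapiens) for cytotoxicity, with a stated time of 48 h (on this read-out higher numbers stand for weaker inhibition and lower numbers for stronger inhibition), compound 1 reaches only the limit of the assay, > 25000 nM, so no number is known for it. Compound 2 `COc1cccc(-c2cc(COC(Cc3cn(C4CCN(Cc5ccc([N+](=O)[O-])cc5)CC4)nn3)c3ccc(Br)cc3)on2)c1` differs from it by a 3-methoxyphenyl in place of 4-methoxyphenyl on an aromatic carbon. In this assay compound 2 likewise stops at the limit, > 25000 nM. The step that the two limits leave unreadable from compound 1 to compound 2 therefore cannot be read. Compound 3 `COc1ccccc1-c1cc(COC(Cc2cn(C3CCN(Cc4ccc([N+](=O)[O-])cc4)CC3)nn2)c2ccc(Br)cc2)on1` carries the change (2-methoxyphenyl in place of 4-methoxyphenyl on an aromatic carbon). Going by the values given here, the only measured step that bears on it is the one from compound 1 to compound 2, whose size stays hidden because of the limit of > 25000 nM in this assay, at which 2 of the 2 values shown sit. No direction or size beyond the scatter can be expected for the move in this assay. The step that the limit leaves unreadable from compound 1 to compound 3 is estimated to leave the result at the limit. Compound 3 is thus expected to give 30000 nM in this assay, within 12000 nM to 80000 nM.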

Compound 3, half-maximal inhibitory concentration: > 25000 nM
Compound 3 gave a limit, no number; the forecaster's own chance of this, stated with the estimate: 85%; the middle value does not contradict the limit.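

The steps among compound 1, compound 2 and compound 3 cannot be read in this assay, as each compound gives only a limit: the limit of > 25000 nM in this assay, at which 3 of the 3 values shown sit.

The compounds shown leave open whether 2-methoxyphenyl, 3-methoxyphenyl and 4-methoxyphenyl differ at all in this assay.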